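The compounds below may be only part of what the source reports. "The series", "measured", "known", "first", "only" and "open" are said of these compounds alone.

Compound 1 `CC(C)Oc1ccc(Br)cc1C(C)NC(=O)NS(=O)(=O)c1ccccc1` gives 143000 nM in a functional assay on thoracic aorta (Rattus norvegicus, strain Wistar), with a stated time of 15 min (a higher number here means that more compound is needed for the effect, a lower number that less compound is needed), the highest of the two numbers measured, so more of it is needed than of any other compound here. Its nearest neighbour is compound 2 `Cc1ccc(S(=O)(=O)NC(=O)NC(C)c2cc(Br)ccc2OC(C)C)cc1`, which in this assay gives 61800 nM; the step of a 2.3-fold lower number from compound 1 to compound 2 (0.36 log units; beyond the scatter) comes from a methyl in place of hydrogen on an aromatic carbon and lies beyond the scatter.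

Compound 3 `COc1ccc(Br)cc1C(C)NC(=O)NS(=O)(=O)c1ccccc1` differs from compound 1 at another place: methyl in place of isopropyl on an oxygen on an aromatic ring. Among the measured compounds shown here, no measured step touches this oxygen, and the one step on record, a 2.3-fold lower number from compound 1 to compound 2 (0.36 log units; beyond the scatter), concerns a different part of the shared core, so it cannot be carried over directly. With nothing to point either way, the expectation for compound 3 in this assay is a step of no clear size beyond the scatter, expressed as a 1.0-fold higher number from compound 1 to compound 3 (0.02 log units; within the scatter). Compound 3 is therefore estimated at 150000 nM in this assay, with a range from 50000 nM to 450000 nM, the width reflecting how little the two measured compounds say about this change.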

Compound 3, half-maximal effective concentration: > 300000 nM
Compound 3: a limit, no number; the forecaster's own chance of this, stated with the estimate: 20%; middle value at least 2.0-fold (0.30 log units) from the limit.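

For compound 3, this assay gives a limit, > 300000 nM, and not a number. Even so, the change can be read, and methyl in place of isopropyl on the oxygen gives an at least 2.0-fold higher number from compound 1 to compound 3 (0.32 log units; beyond the scatter), the first evidence that this position matters in this assay, and the shift runs opposite in direction to the earlier change on the other aromatic ring, a 2.3-fold lower number from compound 1 to compound 2 (0.36 log units; beyond the scatter). Shortening isopropoxy to methoxy thus raises the number beyond the scatter, but the step has a lower bound and no upper one, so its true size stays unknown, and compound 3 marks the end of the measured range: the limit of > 300000 nM in this assay, at which 1 of the 3 values shown sits.

With only isopropyl and methyl shown on this oxygen, it remains open whether the number follows chain size in a steady way or whether an ethyl group, a longer chain such as butyl, or a benzyl group would take it below the value of compound 1. On these data alone, it also remains open how the methyl on the other aromatic ring would behave in combination with methoxy on this oxygen, and whether replacing the bromine with chlorine would alter either step.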